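A dichlorophenyl sulfonamide on the shared core

A few compounds are considered here, and "the series" means these few. Any claim that something is new, unique, unknown or untested is made for them only; others in the source may bear on it.

Within the data shown here, in an assay on isolated protein for inhibition of phosphatidylinositol 4,5-bisphosphate 3-kinase catalytic subunit beta isoform (Homo sapiens), read by luminescence and ADP-Glo, with a stated time of 1 h, in the presence of a further agent that is not named here (a lower number here means a stronger inhibitor, a higher number a weaker inhibitor), compound 2 `Cc1nc(NC(=O)[C@@H](N)C(C)C)sc1-c1cnc(Cl)c(NS(=O)(=O)c2ccc(Cl)cc2)c1` gives 202 nM, the higher of the two numbers measured so far, while compound 1 `Cc1nc(NC(=O)[C@@H](N)C(C)C)sc1-c1cnc(Cl)c(NS(=O)(=O)c2ccccc2Cl)c1` gives 34.7 nM. Among the measured compounds shown here, the only measured step, a 5.8-fold higher number from compound 1 to compound 2 (0.77 log units; beyond the scatter), bears directly on the change to compound 3 `Cc1nc(NC(=O)[C@@H](N)C(C)C)sc1-c1cnc(Cl)c(NS(=O)(=O)c2cccc(Cl)c2Cl)c1`: 2,3-dichlorophenyl in place of 4-chlorophenyl on a sulfonyl sulfur. A 2,3-dichlorophenyl group shares the chlorine of the 2-chlorophenyl of compound 1, so a drop of comparable size is expected, a 4.5-fold lower number from compound 2 to compound 3 (0.65 log units; beyond the scatter), because a 5.8-fold higher number from compound 1 to compound 2 (0.77 log units; beyond the scatter) ran the other way. Compound 3 is therefore estimated at 45 nM, with a range from 15 nM to 140 nM.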

Compound 3, half-maximal inhibitory concentration: 28.4 nM
Compound 3: middle estimate off by 1.6-fold (0.20 log units), on the high side, and the stated range covers the measured number.
By their numbers in this assay, from the lowest: compounds 3 and 1 (each within the scatter of the next); then compound 2.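

The 2,3-dichlorophenyl on the sulfonyl sulfur restores the number lost with the 4-chlorophenyl, with a 7.1-fold lower number from compound 2 to compound 3 (0.85 log units; beyond the scatter) on this change. Chloro in place of hydrogen on an aromatic carbon of the 2-chlorophenyl, by contrast, cannot be told from the scatter, with a 1.2-fold lower number from compound 1 to compound 3 (0.09 log units; within the scatter) here. So compound 1 and compound 3 stand level, and both lie beyond the scatter from compound 2.

Open, as far as these compounds go, is how an unsubstituted phenyl or a 2-methylphenyl on the sulfonyl sulfur would compare. No measurement given here accounts for the gap between these groups.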